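A larger amine in place of pyrrolidine: compound 3

The source may hold more compounds than are shown below. What is called first, only, known or untested is meant among the compounds shown, and "the series" means these compounds.

Compound 1 `O=C(Nc1ccccc1)Nc1nc(Sc2c[nH]c3ccccc23)cc(N2CCCC2)n1` was tested in a functional assay on A549 cells (Homo sapiens) for inhibition, with a stated time of 72 h (a higher number here means a weaker inhibitor, a lower number a stronger inhibitor), where compound 1 gives 21200 nM. Among the compounds with values here, of the two numbers in hand this is the higher one, and its only neighbour is compound 2 `COc1ccc(NC(=O)Nc2nc(Sc3c[nH]c4ccccc34)cc(N3CCCC3)n2)cc1`: in this assay compound 2 gives 11800 nM, so the step of a 1.8-fold lower number from compound 1 to compound 2 (0.25 log units; within the scatter) does not rise above the scatter. That single change, methoxy in place of hydrogen on an aromatic carbon, therefore says little about the shared core.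

Compound 3 `O=C(Nc1ccccc1)Nc1nc(Sc2c[nH]c3ccccc23)cc(N2CCN(c3ccccn3)CC2)n1` differs from compound 1 at another site: 4-(pyridin-2-yl)piperazin-1-yl in place of pyrrolidin-1-yl on an aromatic carbon. Within the data shown here, no measured step touches this part of the molecule; the one step available, a 1.8-fold lower number from compound 1 to compound 2 (0.25 log units; within the scatter), concerns a different position and is itself within the scatter. There is thus no measured basis for a direction, and the expectation rests on compound 1 alone. Compound 3 is estimated to give 15000 nM in this assay, with a range from 4000 nM to 60000 nM. The step that this estimate implies, a 1.4-fold lower number from compound 1 to compound 3 (0.15 log units; within the scatter), is expected to stay within the scatter.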

Compound 3, half-maximal inhibitory concentration: 30300 nM
Compound 3: the middle estimate sits 2.0-fold (0.31 log units) below what was measured; low and high end bracket the measured number.
By their numbers in this assay, from the lowest: compounds 2, 1 and 3 (each within the scatter of the next, the first and the last beyond it).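

In this assay, the step from pyrrolidin-1-yl to 4-(pyridin-2-yl)piperazin-1-yl is a 1.4-fold higher number from compound 1 to compound 3 (0.16 log units; within the scatter). Within the data shown here, this is the first reading at this position, which compounds 1 and 2 share unchanged, and it shows that a much larger group with two rings and more ring nitrogens can stand on this aromatic carbon with no change that rises above the scatter. Nothing in the data on hand explains this result.

The compounds shown leave open whether the piperazine ring and the pyridin-2-yl group each matter at this position, since they enter together and a single step cannot separate them; 4-methylpiperazin-1-yl or morpholin-4-yl in the same place would speak to that. They also leave open whether any amine at this position can move the number beyond the scatter, and whether the methoxy group of compound 2 would read the same alongside 4-(pyridin-2-yl)piperazin-1-yl.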